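The compounds below may be only part of what the source reports. "The series", "measured", "known", "first", "only" and "open" are said of these compounds alone.

Measured so far:
Compound 1, `COc1cccc(CNCCCNc2ccnc3cc(-c4ccc(F)cc4)ccc23)c1O`, in an ADME assay on HepG2 cells (Homo sapiens) for cytotoxicity, read by luminescence, CellTiter-Glo and ATP content, with a stated time of 72 h; on this read-out higher numbers stand for an effect only at larger amounts of compound and lower numbers for an effect already at smaller amounts: 6840 nM
Compound 2, `COc1cccc(CNCCCNc2ccnc3cc(Oc4ccc(C(C)(C)C)cc4)ccc23)c1O`, in this assay: 1500 nM

Compound 2 stands lowest of the two numbers; its nearest neighbour is compound 1, and the step of a 4.6-fold lower number from compound 1 to compound 2 (0.66 log units; beyond the scatter) separates them. Compound 3, `COc1cccc(CNCCCNc2ccnc3cc(CC(C)C)ccc23)c1O`, is not yet measured. It differs from compound 2 by isobutyl in place of 4-(tert-butyl)phenoxy on an aromatic carbon. For the measured compounds named here, the one measured step, a 4.6-fold lower number from compound 1 to compound 2 (0.66 log units; beyond the scatter), also exchanged the group on this same aromatic carbon, and taking away the 4-(tert-butyl)phenoxy in favour of isobutyl is expected to send the number back upward, by roughly a 3.3-fold higher number from compound 2 to compound 3 (0.52 log units; beyond the scatter). Compound 3 is therefore expected to give about 5000 nM, between 1500 nM and 16000 nM.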

Compound 3, half-maximal effective concentration in the HepG2 assay: 2920 nM
Beside the measured number, compound 3's estimate is 1.7-fold (0.23 log units) above it; the range from low to high includes it.
By their numbers in the HepG2 assay, from the lowest: compounds 2 and 3 (each within the scatter of the next); then compound 1.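

In the HepG2 assay, isobutyl, which has no ring, in place of 4-(tert-butyl)phenoxy gives a 1.9-fold higher number from compound 2 to compound 3 (0.29 log units; within the scatter), so at this aromatic carbon the two groups cannot be told apart despite their difference in size. Isobutyl in place of 4-fluorophenyl gives a 2.3-fold lower number from compound 1 to compound 3 (0.37 log units; beyond the scatter), so an aromatic ring on this carbon is not needed for the lower number. In a physicochemical assay for acid dissociation, compound 2 gives 9.28 and compound 3 gives 9.47, values within the usual scatter of each other.

Nothing available explains these numbers. As far as these compounds go, whether an amine or a carboxylic acid on this carbon would keep the number near those of compound 2 and compound 3 stays open.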